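Dichlorobenzyl isomers in the oxalamide series

The source may report more compounds than this note shows. Statements on the series, on what has been measured and on what is new or still open speak of the compounds shown alone.

Values in a functional assay on Jurkat cells (Homo sapiens); a lower number here means a stronger inhibitor, a higher number a weaker inhibitor:
- compound 1 `C[C@H](NC(=O)C(=O)NCC1CCCCC1)C(=O)N[C@@H](CC(=O)O)C(=O)COc1c(F)c(F)cc(F)c1F`: 19 nM
- compound 2 `Cc1ccc(CNC(=O)C(=O)N[C@@H](C)C(=O)N[C@@H](CC(=O)O)C(=O)COc2c(F)c(F)cc(F)c2F)cc1C`: > 10000 nM, a limit of the assay
- compound 3 `C[C@H](NC(=O)C(=O)NCc1ccc(Cl)cc1Cl)C(=O)N[C@@H](CC(=O)O)C(=O)COc1c(F)c(F)cc(F)c1F`: 165 nM

Of the two values that are true numbers, compound 3 holds the higher at 165 nM, with a modest step of an 8.7-fold higher number from compound 1 to compound 3 (0.94 log units; beyond the scatter). The next structure is compound 4 `C[C@H](NC(=O)C(=O)NCc1cc(Cl)cc(Cl)c1)C(=O)N[C@@H](CC(=O)O)C(=O)COc1c(F)c(F)cc(F)c1F`, and the change is 3,5-dichlorophenyl in place of 2,4-dichlorophenyl on a saturated chain carbon bound to an amide-type nitrogen. Among the measured compounds shown here, no measured step isolates the chlorine positions. The nearest evidence is the large step of an at least 60-fold lower number from compound 2 to compound 3 (1.78 log units; beyond the scatter), which shows that exchanging one substituted phenyl for another can matter greatly here. The large step of an at least 520-fold higher number from compound 1 to compound 2 (2.72 log units; beyond the scatter) points the same way. An expected move towards weaker inhibition is a 3.0-fold higher number from compound 3 to compound 4 (0.48 log units; beyond the scatter), with wide uncertainty. Compound 4 is estimated at 500 nM, within an expected range of 100 nM to 4000 nM.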

Compound 4, half-maximal inhibitory concentration: 23 nM
The estimate for compound 4 lay 22-fold (1.34 log units) above the measured number; the whole stated range lies above it.
By their numbers in this assay, from the lowest: compounds 1 and 4 (each within the scatter of the next); then compound 3. At a limit, above all of these: compound 2.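

Moving the chlorines alone matters at this position: with the same atoms, joined differently, the benzyl isomers differ clearly (a 7.2-fold lower number from compound 3 to compound 4 (0.86 log units; beyond the scatter)). The 3,5-dichlorophenyl group also places an aromatic ring here with no loss against the saturated cyclohexyl group (a 1.2-fold higher number from compound 1 to compound 4 (0.08 log units; within the scatter)). Compound 2 stands at a limit of the assay, so its step reads only as a bound (an at least 430-fold lower number from compound 2 to compound 4 (2.63 log units; beyond the scatter)): the limit of > 10000 nM in this assay, at which 1 of the 4 values shown sits.

Open, going by these compounds, is whether the substitution pattern of the 3,5-dichlorophenyl group itself carries over to other substituents, such as methyl or fluorine. A pyridyl ring in this place is equally untested in the compounds shown.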